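From Dimethylamino to Diethylamino on a Carbonyl Carbon

A few compounds are considered here, and "the series" means these few. Any claim that something is new, unique, unknown or untested is made for them only; others in the source may bear on it.

In a functional assay on SMMC-7721 cells (Homo sapiens) for antiproliferative activity, read by MTT assay, with a stated time of 48 h (a lower number here means a stronger inhibitor, a higher number a weaker inhibitor), compound 1 (`CC(C)=CCC[C@]1(C)/C=C/[C@@H](OC(=O)C=C(C)C)[C@](C)(O)/C=C/C(=O)/C(CN(C)C)=C\C1`) gives 820 nM, compound 2 (`CC(C)=CCC[C@]1(C)/C=C/[C@@H](OC(=O)C=C(C)C)[C@](C)(O)/C=C/C(=O)/C(CN2CCN(C)CC2)=C\C1`) gives 2940 nM and compound 3 (`CC(C)=CCC[C@]1(C)/C=C/[C@@H](OC(=O)C=C(C)C)[C@](C)(O)/C=C/C(=O)/C(C(=O)N(C)C)=C\C1`) gives 3670 nM. Compound 3 is thus level with one neighbour and clearly weaker than the other: a 1.2-fold higher number from compound 2 to compound 3 (0.10 log units; within the scatter), but a 4.5-fold higher number from compound 1 to compound 3 (0.65 log units; beyond the scatter). Compound 4 (`CCN(CC)C(=O)/C1=C/C[C@](C)(CCC=C(C)C)/C=C/[C@@H](OC(=O)C=C(C)C)[C@](C)(O)/C=C/C1=O`) makes one change, diethylamino in place of dimethylamino on a carbonyl carbon. Within the data shown here, no measured step makes this exact swap. The closest is a 3.6-fold higher number from compound 1 to compound 2 (0.55 log units; beyond the scatter), which also exchanges the amine group, but on a saturated chain carbon, so it is only a loose guide. In this assay, the expected step is small, a 1.1-fold higher number from compound 3 to compound 4 (0.04 log units; within the scatter), and not beyond the scatter. Compound 4 is estimated at 4000 nM, with an expected range of 1700 nM to 9000 nM.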

Compound 4, half-maximal inhibitory concentration: 13800 nM
Estimate against measurement, compound 4: 3.5-fold (0.54 log units) below; measured number above the stated range.
By their numbers in this assay, from the lowest: compound 1; then compounds 2 and 3 (each within the scatter of the next); then compound 4.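

Among these compounds, on a carbonyl carbon, the group on the amide nitrogen matters: diethylamino in place of dimethylamino gives a 3.8-fold higher number from compound 3 to compound 4 (0.58 log units; beyond the scatter) in this assay and is the first step from compound 3 that lies beyond the scatter. Compound 4 also stands apart from both chain amines, with a 4.7-fold higher number from compound 2 to compound 4 (0.67 log units; beyond the scatter) and a 17-fold higher number from compound 1 to compound 4 (1.23 log units; beyond the scatter) as the steps. Nothing measured here accounts for this loss of activity.

Still open, as far as these compounds go, is whether pyrrolidin-1-yl on the same carbonyl carbon would read closer to compound 3 or compound 4. Also open, from the compounds shown here alone, is how diethylamino would read on the saturated chain carbon of compound 1.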